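Swapping the Phenylethenyl Arm for a Trimethoxyphenyl

The compounds below may be only part of what the source reports. "The series", "measured", "known", "first", "only" and "open" are said of these compounds alone.

Measured in a functional assay on RXF 393 cells (Homo sapiens) for antiproliferative activity, with a stated time of 48 h; on this read-out lower numbers stand for stronger inhibition of growth and higher numbers for weaker inhibition of growth:
compound 1 `Cc1cc(O)c(C2=NN(c3ccc(S(N)(=O)=O)cc3)C(c3ccccc3O)C2)cc1Cl` gives 3650 nM;
compound 2 `Cc1cc(O)c(C2=NN(c3ccc(S(N)(=O)=O)cc3)C(c3ccccc3Cl)C2)cc1Cl` gives 3090 nM;
compound 3 `Cc1cc(O)c(C2=NN(c3ccc(S(N)(=O)=O)cc3)C(/C=C/c3ccccc3)C2)cc1Cl` gives 6690 nM.

Compound 3 carries the highest number of the three in this assay. Compound 4 `COc1ccc(C2CC(c3cc(Cl)c(C)cc3O)=NN2c2ccc(S(N)(=O)=O)cc2)c(OC)c1OC` differs from it in one place: 2,3,4-trimethoxyphenyl in place of 2-phenylethenyl on a saturated ring carbon. Within the data shown here, two measured steps bear on this change, both replacing an aryl group at that saturated ring carbon with the phenylethenyl chain: a 1.8-fold higher number from compound 1 to compound 3 (0.26 log units; within the scatter) and a 2.2-fold higher number from compound 2 to compound 3 (0.34 log units; beyond the scatter). Reversing that direction, the return to an aryl group is expected to bring a modest drop in the number. Compound 4 is therefore expected to show a 1.9-fold lower number from compound 3 to compound 4 (0.28 log units; within the scatter), landing at an estimated 3500 nM in this assay, within a range from 1500 nM to 8000 nM.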

Compound 4, concentration for 50% growth inhibition: 2900 nM
The estimate for compound 4 lay 1.2-fold (0.08 log units) above the measured number; the range from low to high includes it.
By their numbers in this assay, from the lowest: compounds 4, 2, 1 and 3 (each within the scatter of the next, the first and the last beyond it).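

In this assay at this saturated ring carbon, 2,3,4-trimethoxyphenyl in place of 2-phenylethenyl gives a 2.3-fold lower number from compound 3 to compound 4 (0.36 log units; beyond the scatter) and so clears the scatter, which the step from compound 1 to compound 3 did not. Against the other aryl groups it gives a 1.1-fold lower number from compound 2 to compound 4 (0.03 log units; within the scatter) and a 1.3-fold lower number from compound 1 to compound 4 (0.10 log units; within the scatter) and so cannot be told apart from either. No measurement here explains this result. Open, as far as these compounds go, is whether an aryl group carrying a single methoxy, an amine or a carboxylic acid at this carbon stays level with compound 4.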